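This account rests on a few compounds, and the source may have more. Where it says the series, first, only, none or still open, it means among the compounds named here.

Three analogues sharing one core were examined in a functional assay on U-87MG ATCC cells for antiproliferative activity against U-87 MG (Homo sapiens), read by MTT assay, with a stated time of 48 h, tested at 100 uM; a higher number here means a weaker effect of the compound at the concentration tested, a lower number a stronger effect. Compound 2 `Cc1nc(-c2ccccc2)sc1C(=O)CSc1nc(-c2ccccc2)c(C#N)c(=O)[nH]1` gives 9.23%. Compound 1 `Cc1nc(-c2ccccc2)sc1C(=O)CSc1nc(-c2cccc(Cl)c2)c(C#N)c(=O)[nH]1` differs from it by chloro in place of hydrogen on an aromatic carbon, and in this assay compound 1 gives 10%, a step of a number 0.8 percentage points higher from compound 2 to compound 1 (within the scatter). Compound 3 `COc1ccc(-c2nc(C)c(C(=O)CSc3nc(-c4ccccc4)c(C#N)c(=O)[nH]3)s2)cc1` differs from compound 2 by methoxy in place of hydrogen on an aromatic carbon; in this assay compound 3 gives 10.9%, a step of a number 1.7 percentage points higher from compound 2 to compound 3 (within the scatter). Compound 4 `COc1ccc(-c2nc(C)c(C(=O)CSc3nc(-c4cccc(Cl)c4)c(C#N)c(=O)[nH]3)s2)cc1` has not yet been measured. It differs from compound 3 by chloro in place of hydrogen on an aromatic carbon, the same change that separates compound 2 and compound 1, at the same place. Because the earlier step was a number 0.8 percentage points higher from compound 2 to compound 1 (within the scatter), compound 4 is expected to show a step of a number 0.8 percentage points higher from compound 3 to compound 4 (within the scatter). The estimated value for compound 4 is 11.7%, lying between 4% and 20%.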

Compound 4, a percentage reported as activity, at one concentration (the size of the read-out at that concentration, not a potency): 40.6%
Beside the measured number, compound 4's estimate is 28.9 percentage points below it; the measured number lies above the stated range.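

In this assay, chloro in place of hydrogen on an aromatic carbon gave a number 29.7 percentage points higher from compound 3 to compound 4 (beyond the scatter), so this change did not carry over unchanged from one core to the other: the same change on two cores in this assay, a number 0.8 percentage points higher (within the scatter) from compound 2 to compound 1 and a number 29.7 percentage points higher (beyond the scatter) from compound 3 to compound 4, 28.9 percentage points apart, beyond the scatter of two such steps. The addition of the methoxy group gave a number 30.6 percentage points higher from compound 1 to compound 4 (beyond the scatter), and it did not carry over either: the same change on two cores in this assay, a number 1.7 percentage points higher (within the scatter) from compound 2 to compound 3 and a number 30.6 percentage points higher (beyond the scatter) from compound 1 to compound 4, 28.9 percentage points apart, beyond the scatter of two such steps. The two changes therefore do not simply add up in this series, but a single compound carrying both cannot show why, nor whether the same holds at other concentrations or in other cells.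

The compounds shown leave open whether a fluoro or a methyl group in place of the chloro would behave in the same way. They also leave open whether an amine or a hydroxy group in place of the methoxy would do so.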